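Nitro for hydrogen on the thiazole-side phenyl of compound 3

This account rests on a few compounds, and the source may have more. Where it says the series, first, only, none or still open, it means among the compounds named here.

Compound 3, `Cc1ccc(-n2c(Nc3nc(-c4ccccc4)cs3)n[nH]c2=S)cc1`, stands at the high end of the three numbers in hand: in a functional assay on the whole organism (strain Swiss albino) for inhibition, with Mus musculus as the target, with a stated time of 0.5 h (a lower number here means that less compound is needed, a higher number that more compound is needed for the effect), compound 3 gives 300 mg/kg. Compound 1, `Cc1ccccc1-n1c(Nc2nc(-c3ccc(Br)cc3)cs2)n[nH]c1=S`, gives 100 mg/kg in this assay, and compound 2, `COc1ccccc1-n1c(Nc2nc(-c3ccc(Cl)cc3)cs2)n[nH]c1=S`, gives 100 mg/kg; both carry a halogen on the phenyl that compound 3 leaves bare, but each also differs from compound 3 elsewhere, so no single-change comparison exists among the measured set. Compound 4, `Cc1ccc(-n2c(Nc3nc(-c4ccc([N+](=O)[O-])cc4)cs3)n[nH]c2=S)cc1`, differs from compound 3 by nitro in place of hydrogen on an aromatic carbon, the place being para to a large group. Among the measured compounds shown here, with no measured step for this change, a modest movement toward a lower number is expected, a 2.0-fold lower number from compound 3 to compound 4 (0.30 log units; within the scatter), leaning on the values of compound 1 and compound 2. Compound 4 is estimated at 150 mg/kg, within 60 mg/kg to 300 mg/kg.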

Compound 4, minimum effective dose: 300 mg/kg
Estimate against measurement, compound 4: 2.0-fold (0.30 log units) below; the measured number falls inside the stated range.
By their numbers in this assay, from the lowest: compounds 1 and 2 (each within the scatter of the next); then compounds 3 and 4 (each within the scatter of the next).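

In this assay, among the compounds shown here, nitro in place of hydrogen on an aromatic carbon, para to a large group, gives no change at the digits printed from compound 3 to compound 4 (within the scatter) and provides the first single-change step. With the rest of compound 3 held fixed, phenyl to 4-nitrophenyl therefore leaves the minimum effective dose unmoved at this place. No evidence on hand bears on this result. Open remain an amine or a carboxylic acid at this place. Also open, going by these compounds, are bromo and chloro here on the otherwise unchanged compound 3, since compound 1 and compound 2 differ from it in more than one place.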